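Small Ring Swap, Cytotoxicity Expected to Stay Put

The source may hold more compounds than are shown below. What is called first, only, known or untested is meant among the compounds shown, and "the series" means these compounds.

Measured compounds:
Compound 1 `C[C@H]1Cn2ncc(N3CC(c4ccccc4)CC3=O)c2CN1S(=O)(=O)Nc1cc(F)c(F)c(F)c1` gives > 2000 nM, a limit of the assay.
Compound 2 `O=C1CC(Oc2ncc(F)cn2)CN1c1cnn2c1CN(C(=O)Nc1cc(F)c(F)c(F)c1)C(C1CC1)C2` gives 96200 nM.
Compound 3 `CC1(C)CN(C(=O)Nc2cc(F)c(F)c(F)c2)Cc2c(N3CC(C#N)CC3=O)cnn21` gives > 200000 nM, a limit of the assay.

Going by the values given here, in a toxicity assay on HepG2 2.2.15 cells (Homo sapiens) for cytotoxicity, read by CellTiter-Glo (a lower number here means that less compound is tolerated, a higher number that more compound is tolerated), compound 2 is the only compound of the three with an actual number. Compound 1 sits at the limit of > 2000 nM in this assay, at which 1 of the 3 values shown sits. Compound 3 sits at the limit of > 200000 nM in this assay, at which 1 of the 3 values shown sits. Among the compounds with values here, neither limit can be set against the number for compound 2, so no measured step between two compounds is available here.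

Compound 4 `O=C1CC(c2ncco2)CN1c1cnn2c1CN(C(=O)Nc1cc(F)c(F)c(F)c1)C(C1CC1)C2` has not yet been measured. It differs from compound 2 in one place: 1,3-oxazol-2-yl in place of (5-fluoropyrimidin-2-yl)oxy on a saturated ring carbon. The group that leaves and the group that enters are both small aromatic rings with two hetero atoms and no charge, and the rest of the molecule is the same.

Within the data shown here, with no measured step to draw on, the expectation rests on compound 2 alone. The change from compound 2 to compound 4 is expected to leave this assay roughly unchanged, with the step of a 1.0-fold higher number from compound 2 to compound 4 (0.02 log units; within the scatter) not beyond the scatter in either direction. Compound 4 is therefore estimated at 100000 nM, somewhere between 40000 nM and 200000 nM.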

Compound 4, half-maximal cytotoxic concentration: > 200000 nM
Compound 4 gave a limit, no number; the forecaster's own chance of this, stated with the estimate: 30%; middle value at least 2.0-fold (0.30 log units) away from the limit.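

In this assay, exchanging one uncharged aromatic ring group for another on this saturated ring carbon gives an at least 2.0-fold higher number from compound 2 to compound 4 (0.31 log units; beyond the scatter), so the position is not indifferent to what it carries. The larger (5-fluoropyrimidin-2-yl)oxy group goes with the only actual number among the compounds shown, as compound 2 gives 96200 nM. The full size of this step stays unknown, since compound 4 reads as a limit of the assay and not as a number: the limit of > 200000 nM in this assay, at which 2 of the 4 values shown sit.

The compounds shown leave open whether the step follows the change of ring or the loss of the oxygen link, for the two change together in this swap. As far as these compounds go, how an amine or a carboxylic acid on this same ring carbon would read in this assay also remains open.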